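A few compounds are considered here, and "the series" means these few. Any claim that something is new, unique, unknown or untested is made for them only; others in the source may bear on it.

Measured so far:
Compound 1 `Cc1cc2c(C(C)C)ccc(C)c2cc1OC(=O)c1cccc(C(F)(F)F)c1`: "not active" (no number reported)
Compound 2 `CC1=CC[C@H](C(C)C)c2cc(C)c(OC(=O)Nc3ccccc3)cc21`: 92%

For the measured compounds named here, in a functional assay on HCT-15 cells (Homo sapiens) for antiproliferative activity, read by sulforhodamine B assay, with a stated time of 48 h, tested at 50 uM (a higher number here means more inhibition at the concentration tested (going by the name of the read-out), a lower number less inhibition), compound 2 gives 92%, the only number reported here. In this assay compound 1 is reported as "not active" (no number reported), with no figure. Compound 3 `CC1=CC[C@H](C(C)C)c2cc(C)c(OC(=O)c3cccc(C)c3)cc21` differs from compound 2 by 3-methylphenyl in place of anilino on a carbonyl carbon. Going by the values given here, no step between measured compounds is known, so the expected size of the step in this assay is uncertain, but a drop is expected because compound 1 gives "not active" (no number reported) while being an ester too. Compound 3 is expected to give 55%, between 15% and 90%. The expected step is a number 37 percentage points lower from compound 2 to compound 3 (beyond the scatter).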

Compound 3, a percentage reported as inhibition, at one concentration (the size of the read-out at that concentration, not a potency): 5.3%
Beside the measured number, compound 3's estimate is 49.7 percentage points above it; the measured number lies below the stated range.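

In this assay, putting 3-methylphenyl in place of anilino on a carbonyl carbon brings a large loss, a number 86.7 percentage points lower from compound 2 to compound 3 (beyond the scatter). Both groups carry one six-membered aromatic ring of carbon only, so the activity of compound 2 depends on more than having such a ring at this position; anilino also brings a nitrogen and a hydrogen-bond donor. Nothing shown here explains the loss. Still open, as far as these compounds go, is whether the nitrogen alone or its hydrogen counts, which an N-methylanilino group would separate. A plain phenyl group would show whether the ring methyl plays any part.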